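The source may hold more compounds than are shown below. What is called first, only, known or untested is meant among the compounds shown, and "the series" means these compounds.

The series shares the core of compound 1 `Cc1ccc(S/C(=C/c2c(O)cc(O)cc2O)C(=O)c2ccc(Cl)cc2)cc1`, which in a functional assay on DU-145 cells (Homo sapiens) for inhibition, read by trypan blue exclusion, with a stated time of 96 h (a lower number here means a stronger inhibitor of growth, a higher number a weaker inhibitor of growth), gives only a limit, > 100000 nM. Compound 2 `Cc1ccc(S(=O)(=O)/C(=C/c2ccc(Oc3ccccc3)cc2)C(=O)c2ccc(Cl)cc2)cc1` gives 1000 nM in this assay. Compound 3 `Cc1ccc(S(=O)(=O)/C(=C/c2ccc(N(C)C)cc2)C(=O)c2ccc(Cl)cc2)cc1` is again reported only as a limit in this assay, > 100000 nM. The one counted step, an at least 100-fold higher number from compound 2 to compound 3 (2.00 log units; beyond the scatter), leaves compound 3 at the weak end of the numbers shown, as the limit of > 100000 nM in this assay, at which 2 of the 3 values shown sit, records. Compound 4 `Cc1ccc(S(=O)(=O)/C(=C/c2c(O)cc(O)cc2O)C(=O)c2ccc(Cl)cc2)cc1` differs from compound 3 in one place: 2,4,6-trihydroxyphenyl in place of 4-(dimethylamino)phenyl on a double-bonded chain carbon bound to a double-bonded chain carbon. Going by the values given here, no measured step pairs this change directly; the only counted step concerns a different substitution, and compound 1, which carries the same trihydroxyphenyl group, is itself at the limit (the limit of > 100000 nM in this assay, at which 2 of the 3 values shown sit). For compound 4 no movement beyond the scatter is therefore expected in this assay, and the estimate is 100000 nM, within 20000 nM to 300000 nM. The expected step, a number no higher from compound 3 to compound 4 (the limit leaves the size open), is set accordingly, with a limit rather than a number the likeliest outcome.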

Compound 4, concentration for 50% growth inhibition: > 100000 nM
Compound 4: only a limit was reported; the forecaster's own chance of this, stated with the estimate: 65%; the middle value lies on the limit itself.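

Compound 4 is reported only as a limit, and so are compound 1 and compound 3, so neither step to compound 4 can be read: the limit of > 100000 nM in this assay, at which 3 of the 4 values shown sit.

The compounds shown leave open how far either 2,4,6-trihydroxyphenyl or (4-methylphenyl)sulfonyl in place of (4-methylphenyl)sulfanyl shifts growth inhibition.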